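Trifluoromethyl for fluoro: a step without a direct precedent

The compounds below may be only part of what the source reports. "The series", "measured", "known", "first", "only" and "open" are said of these compounds alone.

Measured in a functional assay on A549 cells (Homo sapiens) for cytotoxicity, read by MTT assay, with a stated time of 72 h; a higher number here means a weaker inhibitor, a lower number a stronger inhibitor:
compound 1 `O=C(Nc1ccc(Oc2ccnc3[nH]ccc23)cc1)c1cc(-c2ccc(C(F)(F)F)cc2)ncn1` gives 9380 nM
compound 2 `COc1ccc(-c2cc(C(=O)Nc3ccc(Oc4ccnc5[nH]ccc45)c(F)c3)ncn2)cc1` gives 4210 nM
compound 3 `O=C(Nc1ccc(Oc2ccnc3[nH]ccc23)c(F)c1)c1cc(-c2ccc(F)cc2)ncn1` gives 14200 nM

Compound 3 gives a higher number than compound 2, a gap beyond the scatter, while compound 3 and compound 1 lie within the scatter of each other. The step to compound 4 `O=C(Nc1ccc(Oc2ccnc3[nH]ccc23)c(F)c1)c1cc(-c2ccc(C(F)(F)F)cc2)ncn1` is trifluoromethyl in place of fluoro on an aromatic carbon. Going by the values given here, no measured step swaps fluoro for trifluoromethyl directly. Among the compounds with values here, the only step at that place is a 3.4-fold higher number from compound 2 to compound 3 (0.53 log units; beyond the scatter), a different group. Compound 1 carries the trifluoromethyl but differs from compound 3 elsewhere too, and the two values are within the scatter. The expected step is therefore a 1.4-fold lower number from compound 3 to compound 4 (0.15 log units; within the scatter), small. Compound 4 is estimated at 10000 nM, ranging from 4000 nM to 30000 nM.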

Compound 4, half-maximal inhibitory concentration: 2220 nM
For compound 4 the middle estimate is 4.5-fold (0.65 log units) above the measured one; measured number below the stated range.
By their numbers in this assay, from the lowest: compounds 4 and 2 (each within the scatter of the next); then compounds 1 and 3 (each within the scatter of the next).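

In this assay this place proves sensitive to the swap of 4-fluorophenyl for 4-(trifluoromethyl)phenyl, with a 6.4-fold lower number from compound 3 to compound 4 (0.81 log units; beyond the scatter) as the step. Trifluoromethyl and methoxy, by contrast, cannot be told apart here, with a 1.9-fold lower number from compound 2 to compound 4 (0.28 log units; within the scatter) as the step. With trifluoromethyl held fixed, adding a fluoro elsewhere in the molecule also counts, with a 4.2-fold lower number from compound 1 to compound 4 (0.63 log units; beyond the scatter) as the step, a one-place comparison that compound 1 and compound 3 could not give.

From the compounds shown here alone, how an amine or a nitrile at this place would read remains open. Nothing measured here explains the sizes of these steps.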